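The source may hold more compounds than are shown below. What is called first, only, known or untested is meant among the compounds shown, and "the series" means these compounds.

Of the compounds shown here, three sharing one core have been tested in a functional assay on DLD-1 cells (Homo sapiens) for inhibition, with a stated time of 48 h; on this read-out higher numbers stand for weaker inhibition and lower numbers for stronger inhibition. Compound 1 `COc1cc2oc(/C=C/[S+](C)[O-])cc(=O)c2cc1O` gives only a limit, > 10000 nM. Compound 2 `COc1cc2oc(/C=C/[S+](C)[O-])cc(=O)c2cc1OC` gives 4200 nM and compound 3 `COc1ccc2c(=O)cc(/C=C/[S+](C)[O-])oc2c1` gives 1800 nM, so compound 2 holds the higher of the two true numbers. Compound 4 `COc1ccc2oc(/C=C/[S+](C)[O-])cc(=O)c2c1` has not yet been measured. It departs from compound 2 by a single change, hydrogen in place of methoxy on an aromatic carbon, ortho to a methoxy group.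

For the measured compounds named here, the closest precedent is a 2.3-fold lower number from compound 2 to compound 3 (0.37 log units; beyond the scatter), which is the same exchange made at the other methoxy group of compound 2. The steps of an at least 2.3-fold lower number from compound 1 to compound 2 (0.37 log units; beyond the scatter) and an at least 5.5-fold lower number from compound 1 to compound 3 (0.74 log units; beyond the scatter) both start from the limit of compound 1, so they give no exact size. Going by the values given here, no measured step removes this particular methoxy group, which means the precedent carries over only loosely. A lower number of about the same modest size is therefore expected in this assay, although a smaller change would not surprise. The estimate means a 2.1-fold lower number from compound 2 to compound 4 (0.32 log units; beyond the scatter). Compound 4 is expected at 2000 nM, with an estimated range from 800 nM to 5500 nM.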

Compound 4, half-maximal inhibitory concentration: 1100 nM
Beside the measured number, compound 4's estimate is 1.8-fold (0.26 log units) above it; the range from low to high includes it.
By their numbers in this assay, from the lowest: compounds 4 and 3 (each within the scatter of the next); then compound 2. At a limit, above all of these: compound 1.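

In this assay, taking away this methoxy group, which sits ortho to a methoxy group, gives a 3.8-fold lower number from compound 2 to compound 4 (0.58 log units; beyond the scatter). For the compounds shown here, until now the only readable step of this kind was the exchange at the other methoxy group of compound 2, so this result shows that the same change at a second position also lowers the number, and by a step beyond the scatter. Compound 3 at 1800 nM and compound 4 at 1100 nM lie within the scatter of each other, so on these numbers neither position can be placed ahead of the other, and a single methoxy group at either position goes with a lower number than the two together in compound 2.

On these data alone, what an amine, a chlorine atom or a longer chain such as ethoxy would do at this position stays open, as does the result of replacing the remaining methoxy group of compound 4 with hydrogen. Compound 1 stays a limit, so the size of any step from it cannot be read: the limit of > 10000 nM in this assay, at which 1 of the 4 values shown sits.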